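From acetyl to ethoxy on a compound without a number

A few compounds are considered here, and "the series" means these few. Any claim that something is new, unique, unknown or untested is made for them only; others in the source may bear on it.

Compound 1 `O=C(c1oc(C(F)(F)F)nc1-c1ccccc1F)N1CCN(c2cccc(Cl)c2)CC1` gives "not active" (no number reported)
Compound 2 `Cc1nc(-c2ccccc2)c(C(=O)N2CCN(c3cccc(Cl)c3Cl)CC2)o1` gives 133 nM
Compound 3 `CC(=O)c1ccc(N2CCN(C(=O)c3oc(C)nc3-c3ccccc3)CC2)cc1` gives "not active" (no number reported)

For the measured compounds named here, these three results come from a functional assay on HL-60 cells (Homo sapiens) for inhibition, read by MTT assay, with a stated time of 72 h (a lower number here means a stronger inhibitor, a higher number a weaker inhibitor), and only compound 2 has a number so far. The entry for compound 3 reads "not active" (no number reported) and so offers no figure to start from, and compound 1 reads "not active" (no number reported) in the same way.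

Compound 4 `CCOc1cccc(N2CCN(C(=O)c3oc(C)nc3-c3ccccc3)CC2)c1` has not been measured yet. The structural change is 3-ethoxyphenyl in place of 4-acetylphenyl on an amine nitrogen in a ring and it puts 3-ethoxyphenyl in place of 4-acetylphenyl on an amine nitrogen in a ring.

Without a number for compound 3, the size of this step cannot be worked out exactly. The expected direction is towards stronger inhibition, from no number to a weak but countable value, although another result without a number is about as likely. Compound 2 at 133 nM shows that a number is possible in this small set, but it is a single case, so compound 4 is expected to be a weaker inhibitor than that. The estimated value for compound 4 in this assay is 900 nM with an expected range from 150 nM to 6000 nM if a number is reported at all.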

Compound 4, half-maximal inhibitory concentration: 151 nM
Compound 4: the middle estimate sits 6.0-fold (0.78 log units) above what was measured, within the range that was stated.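

In this assay the 4-acetylphenyl of compound 3 reads "not active" (no number reported), while the 3-ethoxyphenyl at the same place on the ring amine nitrogen gives compound 4 a real value of 151 nM, so on this shared core the group at this one place separates a missing number from a countable one, though the size of that step cannot be read. For the compounds shown here, the comparison with the only other numbered compound gives a 1.1-fold higher number from compound 2 to compound 4 (0.06 log units; within the scatter), so 3-ethoxyphenyl and 2,3-dichlorophenyl, two quite differently substituted phenyl groups, serve equally well here. Nothing measured in this set offers an explanation for either result.

Still open, going by these compounds, is whether the acetyl group itself or its place on the phenyl ring goes with the missing number, since 4-acetylphenyl and 3-ethoxyphenyl differ in both group and place. Also unknown is how an unsubstituted phenyl, or a phenyl carrying an amine, a carboxylic acid or a longer alkoxy chain, would read on this nitrogen.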